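The compounds below may be only part of what the source reports. "The series", "measured", "known", "first", "only" and "open" are said of these compounds alone.

Compound 1 `COc1ccc(-c2cc(/C=C/C(=O)c3ccc(N)cc3)[nH]n2)cc1`: 95%
Compound 2 `COc1cc(-c2cc(/C=C/C(=O)c3ccc(N)cc3)[nH]n2)cc(OC)c1OC`: 89%

In a functional assay on SF-295 cells (Homo sapiens) for cytotoxicity, read by sulforhodamine B assay, with a stated time of 48 h, tested at 0.1 uM (on this read-out lower numbers stand for a stronger effect and higher numbers for a weaker effect at the one concentration tested), compound 2 gives the lowest of the two numbers, and compound 1 gives a number six points higher, a gap within the scatter. Compound 3 `COc1ccc(-c2cc(/C=C/C(=O)c3ccc(N)cc3)[nH]n2)cc1OC` differs from compound 2 by hydrogen in place of methoxy on an aromatic carbon. Since compound 1 and compound 2 carry different numbers of methoxy groups yet sit within the scatter of each other, no step beyond the scatter is expected from compound 2 to compound 3 in this assay: the expected step is a number 2 percentage points higher from compound 2 to compound 3 (within the scatter). Compound 3 is estimated at 91%, within a range of 80% to 100%.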

Compound 3, a percentage reported as activity, at one concentration (the size of the read-out at that concentration, not a potency): 90%
Beside the measured number, compound 3's estimate is 1 percentage points above it; low and high end bracket the measured number.
By their numbers in this assay, from the lowest: compounds 2, 3 and 1 (each within the scatter of the next).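

Each of these two steps changes a single place, which the earlier pair of compounds did not offer. In this assay, swapping methoxy for hydrogen on this aromatic carbon gives a number 1 percentage points higher from compound 2 to compound 3 (within the scatter), and placing methoxy in place of hydrogen on an aromatic carbon gives a number 5 percentage points lower from compound 1 to compound 3 (within the scatter). Both steps lie within the scatter, so neither change can be told from no change at this one concentration. Nothing measured here bears on what lies behind these results. Going by these compounds, whether an amine or a hydroxyl group on this aromatic carbon would move the number beyond the scatter remains open.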